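The source may report more compounds than this note shows. Statements on the series, on what has been measured and on what is new or still open speak of the compounds shown alone.

Measured compounds:
- compound 1 `CCCOCc1cc(O)c(O)c(Br)c1Br`: 1320 nM
- compound 2 `O=Cc1cc(O)c(O)c(Br)c1Br`: "not determined" (no result reported)
- compound 3 `COCc1cc(O)c(O)c(Br)c1`: "not determined" (no result reported)

Three compounds share a core carrying two hydroxy groups and bromine. Only compound 1 has a number in a functional assay on HCT-116 cells (Homo sapiens) for cytotoxicity, read by MTT assay, with a stated time of 96 h (a lower number here means a stronger inhibitor, a higher number a weaker inhibitor), where compound 1 gives 1320 nM. For compound 2, the analogue carrying a formyl group, no value was determined, and compound 3, which carries a methoxymethyl group and a single bromo group, is the one further entry without a number. So compound 2 stands nowhere on the scale: nothing measured can be said of it.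

Compound 4 `CCOCc1cc(O)c(O)c(Br)c1Br` is the next compound to be tested in this assay. It differs from compound 2 in one place: ethoxymethyl in place of formyl on an aromatic carbon. Compound 4 thus sits close to compound 1 in shape, carrying a chain one carbon shorter, and that is the only measured anchor available. Because compound 1 gives 1320 nM, compound 4 is expected to land near that value, with no direction of change claimed beyond the scatter. Compound 4 is estimated at 1500 nM, within a range from 600 nM to 4000 nM.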

Compound 4, half-maximal inhibitory concentration: 2510 nM
Beside the measured number, compound 4's estimate is 1.7-fold (0.22 log units) below it, within the range that was stated.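

In this assay, among these compounds, the change from the longer ether chain of the first compound to ethoxymethyl gives a 1.9-fold higher number from compound 1 to compound 4 (0.28 log units; within the scatter) and so leaves two numbers that repeat measurements could not separate. Among the compounds shown here, this is the first comparison available at this position of the shared core: on the aromatic carbon that is ortho to a bromo group and para to a hydroxy group, an ether chain can lose its end methyl with no readable change in cytotoxicity, though that finding covers only this one small trim between two chains. No measurement on hand explains why the two chains read alike.

On these data alone, compound 2 still has no number, so how its formyl group compares with either ether chain remains unknown. Also open, as far as these compounds go, is whether a much longer chain, a carboxylic acid or an amine on this same aromatic carbon would keep the number in this region or move it clearly beyond the scatter.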